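The source may report more compounds than this note shows. Statements on the series, on what has been measured and on what is new or still open speak of the compounds shown alone.

Measured compounds: compound 1 `CCO/N=C1\C(=O)N(CCCCCOc2ccc3oc(-c4ccc(OC)cc4)c(C(=O)OCC)c3c2)c2ccc(F)cc21` gives 32 ug/mL in an ADME assay on Vero cells (Chlorocebus sabaeus) for cytotoxicity, read by MTT assay, with a stated time of 72 h; on this read-out lower numbers stand for higher toxicity in this test and higher numbers for lower toxicity in this test; compound 2 `CCOC(=O)c1c(-c2ccc(OC)cc2)oc2ccc(OCCCCCN3C(=O)/C(=N\OC)c4cc(F)ccc43)cc12` gives 32 ug/mL; compound 3 `CCOC(=O)c1c(-c2ccc(OC)cc2)oc2ccc(OCCCN3C(=O)/C(=N\OC)c4cc(OC)ccc43)cc12` gives 128 ug/mL.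

Compound 2 and compound 1 differ by methyl in place of hydrogen on a saturated chain carbon bound to an oxygen on an unsaturated carbon, and the step is no change at the digits printed from compound 2 to compound 1 (within the scatter). Compound 3 stands highest of the three, and its gap to compound 1 and to compound 2 lies beyond the scatter; how its core differs from that of compound 2 is not broken down here. Compound 4 `CCO/N=C1\C(=O)N(CCCOc2ccc3oc(-c4ccc(OC)cc4)c(C(=O)OCC)c3c2)c2ccc(OC)cc21` is not yet measured in this assay. It differs from compound 3 by methyl in place of hydrogen on a saturated chain carbon bound to an oxygen on an unsaturated carbon, the same change as between compound 2 and compound 1. Because no change at the digits printed from compound 2 to compound 1 (within the scatter) showed no movement, the step from compound 3 to compound 4 is expected to be about no change at the digits printed from compound 3 to compound 4 (within the scatter). Compound 4 is therefore estimated at 128 ug/mL, expected to fall between 64 ug/mL and 256 ug/mL.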

Compound 4, half-maximal cytotoxic concentration: 32 ug/mL
Estimate against measurement, compound 4: 4.0-fold (0.60 log units) above; measured number outside the range, below it.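

In this assay, methyl in place of hydrogen on a saturated chain carbon bound to an oxygen on an unsaturated carbon gives a 4.0-fold lower number from compound 3 to compound 4 (0.60 log units; beyond the scatter). The same change therefore does not carry over as an equal step from one core to the other: the same change on two cores in this assay, no change at the digits printed (within the scatter) from compound 2 to compound 1 and a 4.0-fold lower number (0.60 log units; beyond the scatter) from compound 3 to compound 4, 4.0-fold (0.60 log units) apart, beyond the scatter of two such steps

The cores of compound 1 and compound 3 differ in more than one place, and these two pairs do not show which difference separates the steps, nor what the change would do on any other core. The compounds shown leave open how a longer chain, such as propoxy in place of ethoxy, would behave on either core. They also leave open the effect of an amine at the end of that chain.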